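Working notes: methylsulfanyl in place of ethyl

This account rests on a few compounds, and the source may have more. Where it says the series, first, only, none or still open, it means among the compounds named here.

In an ADME assay on Vero cells (Chlorocebus sabaeus) for cytotoxicity, with a stated time of 72 h (on this read-out higher numbers stand for weaker inhibition and lower numbers for stronger inhibition), compound 1 `CCOC(=O)c1cc(/C=C/c2ccccc2C(F)(F)F)on1` stands as "not determined" (no result reported) and offers no comparison. In this assay compound 2 `CCOC(=O)c1cc(/C=C/c2ccccc2CC)on1` gives > 128000 nM as a limit of the assay and not a number. The series therefore holds no single number yet, and the limit of > 128000 nM in this assay, at which 1 of the 2 values shown sits, is all that marks the position of compound 2 on this scale.

Compound 3 `CCOC(=O)c1cc(/C=C/c2ccccc2SC)on1` differs from compound 2 by methylsulfanyl in place of ethyl on an aromatic carbon, ortho to a large group, as counted in methylsulfanyl in place of ethyl on an aromatic carbon and the rest of the structure stays the same.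

Within the data shown here, no step between measured compounds is available to size this change. Among the measured compounds shown here, compound 2 with > 128000 nM is the only guide, and this limit supports an expectation of no change beyond the scatter in this assay and no clear direction. The estimated step is a number no higher from compound 2 to compound 3 (the limit leaves the size open) and it is expected to stay within the scatter. For compound 3 the expected value is 128000 nM with an estimated range from 50000 nM to 256000 nM and a further report as a limit is likely.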

Compound 3, half-maximal inhibitory concentration: > 128000 nM
Compound 3 ended at the assay's limit; the forecaster's own chance of this, stated with the estimate: 75%; the middle value lies on the limit itself.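

In this assay compound 2 and compound 3 both stand at a limit of the assay and not at a number, so no new step can be read between them. The compounds shown leave open whether methylsulfanyl in place of ethyl changes the read-out at all, and in which direction, as the series still holds no single number: the limit of > 128000 nM in this assay, at which 2 of the 3 values shown sit.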